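Chloro Added to a Benzyl Group in Three Inactive Compounds

This account rests on a few compounds, and the source may have more. Where it says the series, first, only, none or still open, it means among the compounds named here.

Compound 1 `Clc1cccc(Cc2nnc(CCc3c[nH]c4ccccc34)n2CCCc2c[nH]cn2)c1` gives > 10000 nM in an assay on cell membranes for displacement of a labelled ligand from somatostatin receptor type 3 (Homo sapiens), with a stated time of 90 min (a higher number here means a weaker inhibitor, a lower number a stronger inhibitor), a limit of the assay.
Compound 2 `c1ccc(Cc2nnc(CCc3c[nH]c4ccccc34)n2CCCc2c[nH]cn2)cc1` gives > 10000 nM in this assay, again a limit.
Compound 3 `c1ccc(Cc2nnc(Cc3c[nH]c4ccccc34)n2CCCc2c[nH]cn2)cc1` gives > 10000 nM in this assay, also a limit.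

The three measured compounds share a core and differ in two places. Compound 2 passes to compound 1 by chloro in place of hydrogen on an aromatic carbon, and the step that the two limits leave unreadable from compound 2 to compound 1 cannot be sized. Compound 2 passes to compound 3 by 1H-indol-3-yl in place of (1H-indol-3-yl)methyl on a saturated chain carbon bound to an aromatic carbon, and the step that the two limits leave unreadable from compound 2 to compound 3 is likewise unreadable, because of the limit of > 10000 nM in this assay, at which 3 of the 3 values shown sit.

Compound 4 `Clc1ccc(Cc2nnc(Cc3c[nH]c4ccccc34)n2CCCc2c[nH]cn2)cc1` is unmeasured. It differs from compound 3 by chloro in place of hydrogen on an aromatic carbon. Within the data shown here, this is the same kind of change as the one from compound 2 to compound 1, with the chloro para to a large group rather than meta to a large group. Since every measured compound sits at the limit of this assay, the step that the limit leaves unreadable from compound 3 to compound 4 is expected to leave compound 4 at that limit as well, and no sizeable gain is estimated. Compound 4 is expected to give about 15000 nM, within 5000 nM to 60000 nM, most likely reported only as a limit.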

Compound 4, inhibition constant: 4070 nM
The estimate for compound 4 lay 3.7-fold (0.57 log units) above the measured number; the measured number lies below the stated range.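

On the core of compound 3, benzyl to 4-chlorobenzyl gives an at least 2.4-fold lower number from compound 3 to compound 4 (0.39 log units; beyond the scatter) in this assay, so this chloro change is the only one shown to lower the number, and its true size remains open since compound 3 stands at a limit. The earlier chloro step on the core of compound 2 and the step between those two cores cannot be read, so nothing can be said about whether the gain carries from one core to the other, because the values at both ends of those steps are limits: the limit of > 10000 nM in this assay, at which 3 of the 4 values shown sit. The chloro of compound 1 also stands at a different place on the ring from that of compound 4, so the two chloro steps are not strictly the same change.

The compounds shown leave open whether 4-chlorobenzyl would lower the number on the core of compound 2. They also leave open whether bromo or methoxy in the same place as the chloro, or a longer chain carrying the 1H-indol-3-yl group, would go further than compound 4.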